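Two Measured Amines and an Expected Third

The source may report more compounds than this note shows. Statements on the series, on what has been measured and on what is new or still open speak of the compounds shown alone.

Compound 1 `O=S(=O)(NCCNCc1ccc(-c2ccccc2)cc1)c1cc(C(F)(F)F)cc(C(F)(F)F)c1`: 2600 nM
Compound 2 `O=S(=O)(NCCCNCc1cccc(Cl)c1)c1cc(C(F)(F)F)cc(C(F)(F)F)c1`: 2200 nM

In a functional assay on A2780 cells (Homo sapiens) for inhibition, read by MTT assay, with a stated time of 72 h (a lower number here means a stronger inhibitor of growth, a higher number a weaker inhibitor of growth), compound 2 gives 2200 nM, the lower of the two numbers, though its gap from compound 1 at 2600 nM lies within the scatter. Compound 3 `COc1ccc(CNCCCNS(=O)(=O)c2cc(C(F)(F)F)cc(C(F)(F)F)c2)cc1` differs from compound 2 by 4-methoxyphenyl in place of 3-chlorophenyl on a saturated chain carbon bound to an amine nitrogen. Within the data shown here, no measured pair shows a change of this kind, so the step of a 1.1-fold higher number from compound 2 to compound 3 (0.06 log units; within the scatter) is expected to be small and inside the scatter, in no firm direction. Compound 3 is therefore estimated at 2500 nM, with a range from 1000 nM to 6500 nM.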

Compound 3, concentration for 50% growth inhibition: 1700 nM
The estimate for compound 3 lay 1.5-fold (0.17 log units) above the measured number; the measured number falls inside the stated range.
By their numbers in this assay, from the lowest: compounds 3, 2 and 1 (each within the scatter of the next).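

In this assay, among these compounds, the step of a 1.3-fold lower number from compound 2 to compound 3 (0.11 log units; within the scatter) is the first one read at this position, where 4-methoxyphenyl in place of 3-chlorophenyl on a saturated chain carbon bound to an amine nitrogen leaves the two compounds unresolved. The position therefore accepts both groups here, though a single pair shows no trend. Nothing available explains this result.

Going by these compounds, whether a carboxylic acid or an unsubstituted phenyl at this place would give a larger step remains open. So does the effect of a longer chain alone, since compound 1 and compound 2 differ in more than one place.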